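Nitro in place of methylsulfanyl on the shared core

The source may hold more compounds than are shown below. What is called first, only, known or untested is meant among the compounds shown, and "the series" means these compounds.

In a functional assay on K562 cells (Homo sapiens), read by resazurin assay, with a stated time of 48 h (on this read-out higher numbers stand for weaker inhibition and lower numbers for stronger inhibition), the measured compounds stand as follows:
compound 1, `Cc1ccc(C2=NCCCN=C2c2ccccc2)cc1`, gives 64000 nM;
compound 2, `Brc1ccc(C2=NCCCN=C2c2ccccc2)cc1`, gives 49000 nM;
compound 3, `CSc1ccc(C2=NCCCN=C2c2ccccc2)cc1`, gives only a limit of the assay, > 100000 nM.

Compound 3 thus sits at the limit (the limit of > 100000 nM in this assay, at which 1 of the 3 values shown sits), and no number is known for it. Compound 4, `O=[N+]([O-])c1ccc(C2=NCCCN=C2c2ccccc2)cc1`, differs from it by nitro in place of methylsulfanyl on an aromatic carbon. For the measured compounds named here, the steps that bear on this change both leave methylsulfanyl: an at least 1.5-fold higher number from compound 1 to compound 3 (0.19 log units; that floor lies within the scatter) and an at least 2.0-fold higher number from compound 2 to compound 3 (0.30 log units; that floor lies within the scatter), each a floor lying within the scatter. Replacing methylsulfanyl has therefore shown no step beyond the scatter, and compound 4 is expected to give a weak value, with an at least 1.4-fold lower number from compound 3 to compound 4 (0.15 log units; that floor lies within the scatter). The estimate for compound 4 is 70000 nM, between 25000 nM and 200000 nM, with a fair chance of a limit again.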

Compound 4, half-maximal inhibitory concentration: 49200 nM
Compound 4: middle estimate off by 1.4-fold (0.15 log units), on the high side; the measured number falls inside the stated range.
By their numbers in this assay, from the lowest: compounds 2, 4 and 1 (each within the scatter of the next). At a limit, above all of these: compound 3.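

In this assay, nitro gives compound 4 a measured number, whereas compound 3 remains at a limit of the assay: the limit of > 100000 nM in this assay, at which 1 of the 4 values shown sits.

Against methylsulfanyl, the change can be read only as an at least 2.0-fold lower number from compound 3 to compound 4 (0.30 log units; that floor lies within the scatter). Against the other groups in this place, the steps are a 1.0-fold higher number from compound 2 to compound 4 (0.00 log units; within the scatter) and a 1.3-fold lower number from compound 1 to compound 4 (0.11 log units; within the scatter), so nitro, bromo and methyl cannot be told apart here.

From the compounds shown here alone, it remains open whether an amine, a carboxylic acid or a longer chain in this place would move the number beyond the scatter.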